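Polyether carbonate and ester series: cytotoxicity on fibroblasts

This account rests on a few compounds, and the source may have more. Where it says the series, first, only, none or still open, it means among the compounds named here.

Measured compounds:
- compound 1, `COCCOCCOCCOCCOCCOCCOC(=O)Oc1c(C(C)C)cccc1C(C)C`: 510000 nM
- compound 2, `COCCOCCOCCOC(=O)Oc1c(C(C)C)cccc1C(C)C`: 2290000 nM
- compound 3, `COCCOCCOCCOCCOCCOCCOCCOCCOCCOCCOCC(=O)Oc1c(C(C)C)cccc1C(C)C`: 490000 nM

All three share a hindered phenol ester head; they differ in the polyether tail. In an ADME assay on L929 cells (Mus musculus) for cytotoxicity, read by MTT assay, with a stated time of 24 h (a higher number here means that more compound is needed for the effect, a lower number that less compound is needed), compound 1 gives 510000 nM and compound 3 gives 490000 nM, two numbers that lie within the scatter of each other, so no order can be read between them. Compound 2 gives 2290000 nM in this assay. Within the data shown here, the step of a 4.5-fold higher number from compound 1 to compound 2 (0.65 log units; beyond the scatter) is the one counted change in the set: hydrogen in place of (2-(2-methoxyethoxy)ethoxy)methyl on a saturated chain carbon bound to an oxygen on a saturated carbon. The difference between the cores of compound 1 and compound 3 is not broken down here.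

Compound 4, `COCCOCCOCCOCCOCCOCCOCCOCC(=O)Oc1c(C(C)C)cccc1C(C)C`, has not been measured in this assay. It stands to compound 3 as compound 2 stands to compound 1: hydrogen in place of (2-(2-methoxyethoxy)ethoxy)methyl on a saturated chain carbon bound to an oxygen on a saturated carbon, at a place that reads the same word for word in both pairs, so this is the same change. Among the measured compounds shown here, the only guide to its size is the step from compound 1 to compound 2, which was modest. For the measured compounds named here, compound 3 carries a longer tail than compound 1, and there is no second pair to show whether the same cut on a longer tail gives a step of the same size, so the expectation is drawn somewhat toward a smaller step.

For compound 4 in this assay the expected step is a 2.0-fold higher number from compound 3 to compound 4 (0.31 log units; beyond the scatter), resting on the measured step of a 4.5-fold higher number from compound 1 to compound 2 (0.65 log units; beyond the scatter). Compound 4 is thus estimated at 1000000 nM, with a plausible range from 450000 nM to 2500000 nM.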

Compound 4, half-maximal effective concentration: 120000 nM
Estimate against measurement, compound 4: 8.3-fold (0.92 log units) above; measured number below the stated range.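

In this assay the replacement of (2-(2-methoxyethoxy)ethoxy)methyl by hydrogen gives a 4.1-fold lower number from compound 3 to compound 4 (0.61 log units; beyond the scatter) and so runs opposite in direction to the step on the core of compound 1, which shows that the change does not carry from one core to the other in this series: the same change on two cores in this assay, a 4.5-fold higher number (0.65 log units; beyond the scatter) from compound 1 to compound 2 and a 4.1-fold lower number (0.61 log units; beyond the scatter) from compound 3 to compound 4, 18-fold (1.26 log units) apart, beyond the scatter of two such steps.
Any reading of this change therefore holds for its own core only, and the step measured on one core gives no usable guide to either the direction or the size of the step on the other. What the two pairs do not show is which difference between the core of compound 1 and the core of compound 3 goes with the reversal, and with one pair on each core they cannot separate a true dependence on the core from a trend that is specific to these particular tail lengths.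

Open, going by these compounds, is how the number moves with tail length on each core, which a longer chain or a further shortened chain on the same core would begin to trace. Also open, on these data alone, is whether a tail carrying an amine or a carboxylic acid in place of the methoxy group would follow either of the two steps.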